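The source may report more compounds than this note shows. Statements on the series, on what has been measured and on what is new or still open speak of the compounds shown alone.

Measured compounds:
- compound 1, `CCOC(=O)C1=C(C)N/C(=C/c2cc(C)n(-c3ccc(CN(C)C)cc3)c2C)C1=O`, in a physicochemical assay for solubility, read by nephelometry, measured as kinetic solubility, at pH 2.0 (a lower number here means a less soluble compound, a higher number a more soluble compound), compound 1 gives 50 ug/mL
- compound 2, `CCOC(=O)C1=C(C)N/C(=C/c2cc(C)n(-c3ccc(N(C)C)cc3)c2C)C1=O`, in this assay compound 2 gives 12.5 ug/mL

Among the compounds with values here, compound 2 stands lowest of the two numbers so far; its nearest neighbour is compound 1, and the single measured step is a 4.0-fold lower number from compound 1 to compound 2 (0.60 log units; beyond the scatter). Compound 3, `CCOC(=O)C1=C(C)N/C(=C/c2cc(C)n(-c3ccc(CN4CCCCC4)cc3)c2C)C1=O`, is not yet measured. The change from compound 2 to compound 3 is (piperidin-1-yl)methyl in place of dimethylamino on an aromatic carbon. Within the data shown here, the one step that bears on it is the reverse of the measured one: shortening the benzylic amine of compound 1 to the directly attached dimethylamino of compound 2 gave a 4.0-fold lower number from compound 1 to compound 2 (0.60 log units; beyond the scatter), a modest step beyond the scatter. Among the measured compounds shown here, compound 3 restores a methylene-linked amine as in compound 1, though with the larger piperidine ring, for which no precedent exists in this set. The expected step is therefore in the upward direction, of roughly the size seen from compound 1 to compound 2, with the unprecedented ring widening the range: the step from compound 2 to compound 3 is estimated as a 2.8-fold higher number from compound 2 to compound 3 (0.45 log units; beyond the scatter). For compound 3 in this assay the estimate is 35 ug/mL, expected to lie between 10 ug/mL and 100 ug/mL.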

Compound 3, solubility: 50 ug/mL
For compound 3 the middle estimate is 1.4-fold (0.15 log units) below the measured one, within the range that was stated.
By their numbers in this assay, from the lowest: compound 2; then compounds 1 and 3 (each within the scatter of the next).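

On the six-membered aromatic ring of carbon only, the (piperidin-1-yl)methyl group reads the same as the (dimethylamino)methyl group in this assay, with no change at the digits printed from compound 1 to compound 3 (within the scatter). The larger amine, with its one six-membered non-aromatic ring, therefore brings no change that can be separated from the scatter at this position. With a 4.0-fold higher number from compound 2 to compound 3 (0.60 log units; beyond the scatter) set beside the earlier 4.0-fold lower number from compound 1 to compound 2 (0.60 log units; beyond the scatter), both amines carried on a methylene now give higher numbers than the directly attached dimethylamino group, so the earlier gap does not rest on the (dimethylamino)methyl group alone, and no measurement shown here explains this.

The linker and the amine remain tied together in this small set, since the only directly attached amine is dimethylamino; a directly attached piperidin-1-yl group would show whether the methylene alone accounts for the gap. On these data alone, it also remains open whether the flat reading between the two methylene-linked amines extends to a morpholine ring, a two-carbon chain ahead of the amine, or a carboxylic acid at the same place.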